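The compounds below may be only part of what the source reports. "The series", "measured", "known", "first", "only" and "open" are said of these compounds alone.

Compound 3 `CC1=CC[C@H](C(C)(C)NC(=S)N/N=C/c2ccccc2O)CC1` carries the 2-hydroxyphenyl group on a carbon with a double bond to nitrogen. Within the data shown here, in a functional assay on 786-0 cells (Homo sapiens) for inhibition, read by sulforhodamine B assay, with a stated time of 48 h (a lower number here means a stronger inhibitor of growth, a higher number a weaker inhibitor of growth), compound 3 gives 12100 nM, the only number among the three measured compounds. Compound 1 `CC1=CC[C@H](C(C)(C)N=C=S)CC1` returns only a limit, > 100000 nM. Compound 2 `CC1=CC[C@H](C(C)(C)NC(=S)NN)CC1` likewise stops at a limit, > 100000 nM. The step that the two limits leave unreadable from compound 1 to compound 2 cannot be read because both sit at the limit of > 100000 nM in this assay, at which 2 of the 3 values shown sit. Compound 4 `CC1=CC[C@H](C(C)(C)NC(=S)N/N=C/c2ccc(Cl)cc2)CC1` differs from compound 3 by 4-chlorophenyl in place of 2-hydroxyphenyl on a carbon with a double bond to nitrogen. Among the measured compounds shown here, no measured step touches this part of the molecule, so the expectation in this assay rests on compound 3 alone, and no step beyond the usual scatter is assumed. Compound 4 is therefore estimated at 15000 nM, between 4000 nM and 60000 nM. This expected step is a 1.2-fold higher number from compound 3 to compound 4 (0.09 log units; within the scatter).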

Compound 4, concentration for total growth inhibition: > 100000 nM
Compound 4: a limit, no number (the forecaster's own chance of this, stated with the estimate: 20%); middle value at least 6.6-fold (0.82 log units) from the limit.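

In this assay, the group on a carbon with a double bond to nitrogen matters: 4-chlorophenyl in place of 2-hydroxyphenyl gives an at least 8.2-fold higher number from compound 3 to compound 4 (0.91 log units; beyond the scatter). Compound 4 gives > 100000 nM, which is a limit and not a number. This single change returns compound 4 to the level of the two compounds without an aryl group, leaving compound 3 alone with a number: the limit of > 100000 nM in this assay, at which 3 of the 4 values shown sit.

The change removes the hydroxyl and adds chlorine together, so the compounds shown cannot separate the two. Going by these compounds, how a plain phenyl or an aminophenyl group would read here remains open.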